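Chloro on the phenyl ring of a triazole tail

This account rests on a few compounds, and the source may have more. Where it says the series, first, only, none or still open, it means among the compounds named here.

Compound 1 `C=C1C[C@]23C[C@@]1(O)CC[C@H]2c1cc(Br)c(O)c(C)c1[C@@H]3Cn1cc(-c2ccc(C)cc2)nn1`: > 20000 nM
Compound 2 `Cc1c(O)ccc2c1[C@H](Cn1cc(-c3ccccc3)nn1)[C@@]13CC(=O)[C@@](C)(CC[C@@H]21)C3`: > 20000 nM
Compound 3 `C=C1C[C@]23C[C@@]1(O)CC[C@@H]2c1cccc(C)c1[C@@H]3Cn1cc(-c2ccccc2)nn1`: > 20000 nM

All three values above come from a functional assay on SMMC-7721 cells (Homo sapiens) for cytotoxicity, read by MTT assay, with a stated time of 4 days (a higher number here means a weaker inhibitor, a lower number a stronger inhibitor), and each is a limit, not a number. Compound 2 therefore stands at the limit in this assay. The same is true of its two companions, since (the limit of > 20000 nM in this assay, at which 3 of the 3 values shown sit). Among the measured compounds shown here, nothing in these results separates compound 2 from compound 1 or compound 3; no step between any two of them can be sized.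

Compound 4 `Cc1c(O)ccc2c1[C@H](Cn1cc(-c3ccc(Cl)cc3)nn1)[C@@]13CC(=O)[C@@](C)(CC[C@@H]21)C3` is built from compound 2 by a single change, (chloro in place of hydrogen on an aromatic carbon). The change leaves the shared core untouched and touches only the outer ring of the tail.

For the measured compounds named here, with every measured compound resting at the limit, there is no step on which to build a direction. The expected outcome is that the change from compound 2 to compound 4 makes no difference beyond the scatter, and the expected step is a step that the limit leaves unreadable from compound 2 to compound 4. Compound 4 is thus estimated at 30000 nM in this assay, within a range from 8000 nM to 120000 nM, most likely appearing again only as a limit.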

Compound 4, half-maximal inhibitory concentration: > 20000 nM
Compound 4: no number, only a limit; the forecaster's own chance of this, stated with the estimate: 80%; the middle value is on the limit's open side.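

Compound 2 and compound 4 both rest at a limit rather than a number, so the step between them cannot be read: the limit of > 20000 nM in this assay, at which 4 of the 4 values shown sit.

The compounds shown leave open how strong any of them truly is, and whether phenyl to 4-chlorophenyl changes anything at all.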